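Swapping the Aryl Group on Sulfur

The source may hold more compounds than are shown below. What is called first, only, known or untested is meant among the compounds shown, and "the series" means these compounds.

In a functional assay on VCaP cells (Homo sapiens) for antiproliferative activity, read by fluorescence and propidium iodide staining, with a stated time of 96 h (a lower number here means a stronger inhibitor, a higher number a weaker inhibitor), compound 1 `CC(O)(CSc1cc(C(F)(F)F)cc(C(F)(F)F)c1)C(=O)Nc1ccc(C#N)cc1C(F)(F)F` gives 6650 nM and compound 2 `CC(O)(CSc1cc(C(F)(F)F)cc(C(F)(F)F)c1)C(=O)Nc1ccc(C(F)(F)F)cc1` gives 9880 nM. Compound 3 `CC(O)(CSc1cccc(C(F)(F)F)c1)C(=O)Nc1cc(C(F)(F)F)cc(C(F)(F)F)c1` gives 9860 nM, which lies within the scatter of both other values. Compound 4 `CC(O)(CSc1ccccc1OC(F)(F)F)C(=O)Nc1cc(C(F)(F)F)cc(C(F)(F)F)c1` carries 2-(trifluoromethoxy)phenyl in place of 3-(trifluoromethyl)phenyl on a sulfur. Among the measured compounds shown here, no measured pair isolates a single change, so the data offer no direct guide to this swap. With compound 3 at 9860 nM as the anchor, no step beyond the scatter is expected in this assay. The expected change is a 1.1-fold lower number from compound 3 to compound 4 (0.04 log units; within the scatter). Compound 4 is estimated at 9000 nM, with an expected range from 3500 nM to 20000 nM.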

Compound 4, half-maximal inhibitory concentration: 2900 nM
Beside the measured number, compound 4's estimate is 3.1-fold (0.49 log units) above it; the measured number lies below the stated range.
By their numbers in this assay, from the lowest: compound 4; then compounds 1, 3 and 2 (each within the scatter of the next).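

In this assay, among the compounds shown here, the aryl group on the sulfur proves able to shift the number: 2-(trifluoromethoxy)phenyl in place of 3-(trifluoromethyl)phenyl gives a 3.4-fold lower number from compound 3 to compound 4 (0.53 log units; beyond the scatter) and is the first single change in this set that can be read. The entering group also brings an oxygen and a hydrogen-bond acceptor, but no measurement here explains the step. Still open, as far as these compounds go, is how 2-(trifluoromethyl)phenyl or 3-(trifluoromethoxy)phenyl on the sulfur would compare, which would separate the identity of the group from its placement.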